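Swapping a Nitro Group for an Ester at the Same Position

The source may report more compounds than this note shows. Statements on the series, on what has been measured and on what is new or still open speak of the compounds shown alone.

Compound 1, `Cc1ccc(C(=O)Nc2cccc(NC(=O)COc3ccc4c(=O)ccoc4c3)c2)cc1`, gives 22 nM.
Compound 2, `O=C(COc1ccc2c(=O)ccoc2c1)Nc1cccc(NC(=O)c2ccc([N+](=O)[O-])cc2)c1`, gives 15 nM.

These two values come from an assay on isolated protein for inhibition of Rho-associated protein kinase 2 (Homo sapiens), read by scintillation counting, radiometric assay and 33P incorporation, with a stated time of 40 min, in the presence of a further agent that is not named here; a lower number here means a stronger inhibitor, a higher number a weaker inhibitor. Compound 2 has the smaller of the two numbers shown, but compound 1 sits close by, and the two are within the usual scatter of each other, so neither can be called the stronger inhibitor.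

Compound 3, `COC(=O)c1ccc(C(=O)Nc2cccc(NC(=O)COc3ccc4c(=O)ccoc4c3)c2)cc1`, is not yet measured. It differs from compound 2 in one place: methoxycarbonyl in place of nitro on an aromatic carbon. For the measured compounds named here, the one measured step that speaks to this position, a 1.5-fold lower number from compound 1 to compound 2 (0.17 log units; within the scatter), exchanged the group on the same aromatic carbon and stayed within the scatter. A second exchange at that carbon is therefore expected to leave the number where it is, giving an estimated 1.3-fold higher number from compound 2 to compound 3 (0.12 log units; within the scatter) in this assay. Compound 3 is expected to give about 20 nM, with a likely range of 7 nM to 60 nM.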

Compound 3, half-maximal inhibitory concentration: 29 nM
Compound 3: middle estimate off by 1.5-fold (0.16 log units), on the low side, and the stated range covers the measured number.
By their numbers in this assay, from the lowest: compounds 2, 1 and 3 (each within the scatter of the next).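

In this assay methoxycarbonyl is a third group on this aromatic carbon, and both a 1.9-fold higher number from compound 2 to compound 3 (0.29 log units; within the scatter) and a 1.3-fold higher number from compound 1 to compound 3 (0.12 log units; within the scatter) stay within the scatter. Methyl, nitro and methoxycarbonyl therefore cannot be told apart here, even though the last two share no more than their oxygen atoms and methyl has neither, so this carbon has now held three quite different groups with no readable change in the number. Nothing measured here explains why these groups read alike.

From the compounds shown here alone, it remains open whether plain hydrogen, an amine, a carboxylic acid or a longer chain on this carbon would move the number beyond the scatter. Going by these compounds, it also remains open whether these same groups would read alike at another place on the ring.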